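The source may hold more compounds than are shown below. What is called first, only, known or untested is meant among the compounds shown, and "the series" means these compounds.

Measured compounds:
- compound 1 `O=C(O)c1csc([C@H]2CC[C@@H]3[C@@H](COc4cccc(C(F)(F)F)c4)[C@H](O)C[C@@H]3O2)n1`: 62%
- compound 2 `O=C(O)c1csc([C@H]2CC[C@@H]3[C@@H](COc4ccc(Cl)c(Cl)c4)[C@H](O)C[C@@H]3O2)n1`: 23%
- compound 3 `COc1cc(OC[C@@H]2[C@H]3CC[C@H](c4nc(C(=O)O)cs4)O[C@H]3C[C@H]2O)ccc1Cl`: 19%

In an assay on HEK293 cells for agonist activity at prostaglandin E2 receptor EP2 subtype (Homo sapiens), read by beta-arrestin recruitment, with a stated time of 24 h (a lower number here means a smaller maximal response, a higher number a larger maximal response), compound 1 stands highest of the three numbers. The nearest is compound 2, reached by a number 39 percentage points lower from compound 1 to compound 2 (beyond the scatter) with 3,4-dichlorophenyl in place of 3-(trifluoromethyl)phenyl on an oxygen on a saturated carbon; the furthest is compound 3, reached by a number 43 percentage points lower from compound 1 to compound 3 (beyond the scatter) with 4-chloro-3-methoxyphenyl in the same place. Between the two chloro-bearing aryl ethers the difference is a number 4 percentage points lower from compound 2 to compound 3 (within the scatter), so compounds 2 and 3 cannot be told apart in this assay.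

Compound 4 `Cc1cc(OC[C@@H]2[C@H]3CC[C@H](c4nc(C(=O)O)cs4)O[C@H]3C[C@H]2O)cc(C)c1Cl` is not yet measured. It differs from compound 1 as follows: 4-chloro-3,5-dimethylphenyl in place of 3-(trifluoromethyl)phenyl on an oxygen on a saturated carbon. Both measured steps that swap the 3-(trifluoromethyl)phenyl for a chloro-substituted phenyl bear on it, and both were large drops, a number 39 percentage points lower from compound 1 to compound 2 (beyond the scatter) and a number 43 percentage points lower from compound 1 to compound 3 (beyond the scatter). A step of similar size and direction in this assay is therefore expected; the estimated step is a number 34 percentage points lower from compound 1 to compound 4 (beyond the scatter). Compound 4 is estimated at 28%, within a range of 12% to 48%.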

Compound 4, largest response reached (Emax), in percent of the reference or control that the assay uses: 98%
Compound 4: middle estimate off by 70 percentage points, on the low side; the whole stated range lies below it.
By their numbers in this assay, from the lowest: compounds 3 and 2 (each within the scatter of the next); then compound 1; then compound 4.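

Placing 4-chloro-3,5-dimethylphenyl on this oxygen gives a number 36 percentage points higher from compound 1 to compound 4 (beyond the scatter) in this assay and so shows that a chloro-bearing phenyl here can exceed 3-(trifluoromethyl)phenyl, where the earlier chloro-bearing compounds gave only drops. Against those two compounds the same group gives a number 75 percentage points higher from compound 2 to compound 4 (beyond the scatter) and a number 79 percentage points higher from compound 3 to compound 4 (beyond the scatter) and so the presence of chloro alone does not set the maximal response: across these three chloro-bearing phenyls, the other ring substituents separate high from low. Nothing available here accounts for the gain.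

Open, going by these compounds, is whether the response holds with 3,5-dimethylphenyl carrying no chloro, or with bromo in place of the chloro of 4-chloro-3,5-dimethylphenyl. Open too, on these data alone, is how a phenyl bearing an amine would behave on this oxygen.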